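Turning one double bond in a weak compound

The compounds below may be only part of what the source reports. "The series", "measured", "known", "first", "only" and "open" are said of these compounds alone.

Compound 1 `COc1cc(/C=C\c2ccc3nccnc3c2)cc(OC)c1OC` gives 7940 nM
Compound 2 `COc1cc(/C=C\c2ccc3nc(C)c(C)nc3c2)cc(OC)c1OC` gives > 15800 nM

Both compounds were tested in a functional assay on SK-MEL-28 cells (Homo sapiens) for cytotoxicity (a lower number here means a stronger inhibitor, a higher number a weaker inhibitor), and neither is strong there. In that test compound 1 gives 7940 nM as a real number. Compound 2 stands at the limit of > 15800 nM in this assay, at which 1 of the 2 values shown sits, and its reading is a limit, not a number.

Compound 3 `COc1cc(/C=C/c2ccc3nc(C)c(C)nc3c2)cc(OC)c1OC` alters compound 2 in one respect only: the two compounds have the same atoms and bonds and differ only in configuration as drawn: 1 of 1 stereo elements differ; a double bond is drawn Z in compound 2 and E in compound 3 and nothing else. Among the measured compounds shown here, no measured pair shows what such a change does, so no gain in strength is assumed. The expected step that the limit leaves unreadable from compound 2 to compound 3 stays within the scatter. Compound 3 is estimated at 20000 nM with an expected range from 12000 nM to 40000 nM in this assay for now.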

Compound 3, half-maximal inhibitory concentration: > 15800 nM
Compound 3 was reported as a limit; the forecaster's own chance of this, stated with the estimate: 75%; the middle value does not contradict the limit.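

Among the compounds shown here, compound 2 and compound 3 both end at a limit in this assay, not at a number, so no step between them can be read. Going by these compounds, whether turning the double bond from Z to E changes strength remains open.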